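A few compounds are considered here, and "the series" means these few. Any claim that something is new, unique, unknown or untested is made for them only; others in the source may bear on it.

Measured so far in an assay on CHO-K1 cells for displacement of a labelled ligand from melanin-concentrating hormone receptor 1 (Homo sapiens), read by scintillation proximity assay, with a stated time of 2 h; on this read-out lower numbers stand for stronger inhibition and higher numbers for weaker inhibition:
compound 1 `Cc1nc(N2CCC(O)(C3CC3)CC2)nc2ccc(NC(=O)/C=C/c3ccc(C(F)(F)F)cc3)cc12`, 232 nM
compound 2 `COc1ccc(/C=C/C(=O)Nc2ccc3nc(N4CCC(O)(C5CC5)CC4)nc(C)c3c2)cc1`, 116 nM

Compound 2 stands at 116 nM in this assay, with compound 1 at 232 nM. The single step joining them, a 2.0-fold lower number from compound 1 to compound 2 (0.30 log units; within the scatter), lies within the scatter, so the two compounds are not separable on the numbers shown; compound 2 merely has the lower of the two readings.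

Compound 3 `Cc1ccc(/C=C/C(=O)Nc2ccc3nc(N4CCC(O)(C5CC5)CC4)nc(C)c3c2)cc1` differs from compound 2 as follows: methyl in place of methoxy on an aromatic carbon.

Within the data shown here, no measured step exchanges methoxy for methyl at this site. Among the measured compounds shown here, the only step available changes the same aromatic carbon from trifluoromethyl to methoxy, and that step, a 2.0-fold lower number from compound 1 to compound 2 (0.30 log units; within the scatter), stayed within the scatter. Nothing in the series therefore points to a shift in this assay beyond the scatter for the present change, in either direction. On that basis, the step of a 1.4-fold higher number from compound 2 to compound 3 (0.14 log units; within the scatter) is expected, essentially no movement outside the scatter. For compound 3 the estimate in this assay is 160 nM, with a range of 70 nM to 380 nM.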

Compound 3, half-maximal inhibitory concentration: 344 nM
Compound 3: the middle estimate sits 2.2-fold (0.33 log units) below what was measured, within the range that was stated.
By their numbers in this assay, from the lowest: compounds 2, 1 and 3 (each within the scatter of the next, the first and the last beyond it).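

Among these compounds, at the aromatic carbon para to a large group, this assay now gives a first step beyond the scatter: a 3.0-fold higher number from compound 2 to compound 3 (0.47 log units; beyond the scatter) for methyl in place of methoxy, a modest change in size. Methyl in place of trifluoromethyl gives a 1.5-fold higher number from compound 1 to compound 3 (0.17 log units; within the scatter) and the three groups therefore do not fall into a simple ladder, since the reading for methoxy is set apart from the reading for methyl but not from the one for trifluoromethyl, where a 2.0-fold lower number from compound 1 to compound 2 (0.30 log units; within the scatter) stays within the scatter. The change that separates compound 2 from compound 3 takes out one oxygen and the one hydrogen-bond acceptor counted in the methoxy group, yet compound 1 and compound 3 remain inseparable on these numbers, so this position shows a real but small sensitivity to the group it carries.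

The compounds shown leave open whether an ethoxy group, a hydroxyl, a chlorine or a dimethylamino group at this carbon would sit with methoxy or with methyl, and whether the step holds on any other core. Nothing at hand bears on why methoxy and methyl part at this carbon.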